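The source may hold more compounds than are shown below. What is called first, only, known or untested is meant among the compounds shown, and "the series" means these compounds.

Measured so far in a functional assay on COLO 205 cells (Homo sapiens) for inhibition, read by sulforhodamine B assay, with a stated time of 48 h; a lower number here means a stronger inhibitor of growth, a higher number a weaker inhibitor of growth:

- compound 1, `COc1cc(-c2nn(-c3cccc(NC(=O)Nc4cc(C(F)(F)F)cc(C(F)(F)F)c4)c3)cc2-c2ccncc2)ccc1Cl`: 847 nM
- compound 2, `COc1cc(-c2nn(-c3cccc(NC(=O)c4cccc(C(F)(F)F)c4)c3)cc2-c2ccncc2)ccc1Cl`: 1640 nM
- compound 3, `O=C(Nc1cccc(-n2cc(-c3ccncc3)c(-c3ccc(Cl)c(O)c3)n2)c1)Nc1cc(C(F)(F)F)cc(C(F)(F)F)c1`: 853 nM

Compound 2 sits at the high end of these three numbers, yet its separation from compound 3 and from compound 1 lies within the usual scatter of this assay, so the three cannot be ranked against one another.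

Compound 4, `COc1cc(-c2nn(-c3cccc(NC(=O)Nc4ccc(Cl)c(C(F)(F)F)c4)c3)cc2-c2ccncc2)ccc1Cl`, has not been measured. It differs from compound 2 by (4-chloro-3-(trifluoromethyl)phenyl)amino in place of 3-(trifluoromethyl)phenyl on a carbonyl carbon. Among the measured compounds shown here, the only step that has been measured, a 1.0-fold higher number from compound 1 to compound 3 (0.00 log units; within the scatter), concerns a different change and does not bear on this one. For the measured compounds named here, compound 1 and compound 2 differ from each other in two places at once, so no single step can be drawn between them; all their values show is that compound 1 at 847 nM and compound 2 at 1640 nM lie within the scatter of each other.

Going by the values given here, with no measured step covering the change itself, the expectation for compound 4 rests on the closeness of all three numbers, and a step of a 1.9-fold lower number from compound 2 to compound 4 (0.29 log units; within the scatter) is therefore expected, nothing beyond the scatter. Compound 4 is estimated at 850 nM, with a range from 350 nM to 2100 nM.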

Compound 4, concentration for 50% growth inhibition: 711 nM
Compound 4: the middle estimate sits 1.2-fold (0.08 log units) above what was measured; the measured number falls inside the stated range.
By their numbers in this assay, from the lowest: compounds 4, 1, 3 and 2 (each within the scatter of the next, the first and the last beyond it).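

In this assay, among the compounds shown here, putting (4-chloro-3-(trifluoromethyl)phenyl)amino in place of 3-(trifluoromethyl)phenyl on the carbonyl carbon gives a 2.3-fold lower number from compound 2 to compound 4 (0.36 log units; beyond the scatter), a modest strengthening of growth inhibition and the first change at this position that can be read on its own, whereas compound 1 and compound 2 differ in two places at once. The step shows that this position responds to the swap, although only slightly, with the entering group bringing an amino nitrogen with its hydrogen-bond donor and a chlorine together, so that this single step credits neither part separately. No measurement available here explains the shift in growth inhibition.

The compounds shown leave open how much of the step belongs to the amino nitrogen and how much to the chlorine, a question that a (3-(trifluoromethyl)phenyl)amino group or a 4-chloro-3-(trifluoromethyl)phenyl group on the same carbonyl carbon would address. Also open, as far as these compounds go, is how the number would respond to a bromine atom or a nitrile in place of that chlorine.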